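The source may hold more compounds than are shown below. What is called first, only, known or untested is meant among the compounds shown, and "the series" means these compounds.

Working notes on the aryl thioether series. For the measured compounds named here, compound 1 `CCOC(=O)c1c(CSc2ccc(OC(F)(F)F)cc2)n(C)c2ccc(O)cc12` is the one analogue with a measured number: in an assay on cells for inhibition of Polyunsaturated fatty acid 5-lipoxygenase (Homo sapiens), read by HPLC, with a stated time of 15 min (on this read-out lower numbers stand for stronger inhibition and higher numbers for weaker inhibition), compound 1 gives 2100 nM. Compound 2 `CCOC(=O)c1c(CSc2cccc(Cl)c2)n(C)c2ccc(O)cc12` carries 3-chlorophenyl on the sulfur. In this assay compound 2 gives only > 10000 nM, which is a limit of the assay and not a number. Compound 2 therefore stands at the limit of > 10000 nM in this assay, at which 1 of the 2 values shown sits. Going by the values given here, with one number and one limit, no step between measured compounds can be stated; the two values show only that compound 1 has a number where compound 2 has none. Compound 3 `CCOC(=O)c1c(CSc2cc(C)cc(C)c2)n(C)c2ccc(O)cc12` is not yet measured. The change from compound 2 is 3,5-dimethylphenyl in place of 3-chlorophenyl on a sulfur. Among the compounds with values here, no measured pair tracks a methyl on this ring, and the start point is a limit, so the direction of the expected step of an at least 1.2-fold lower number from compound 2 to compound 3 (0.09 log units; that floor lies within the scatter) is uncertain; a move no larger than the scatter is the working assumption, with a fair chance that this assay again returns only a limit. Compound 3 is estimated at 8000 nM, expected between 2500 nM and 25000 nM.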

Compound 3, half-maximal inhibitory concentration: 2700 nM
Estimate against measurement, compound 3: 3.0-fold (0.47 log units) above; measured number inside the range.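

Replacing 3-chlorophenyl with 3,5-dimethylphenyl on the sulfur gives, in this assay, an at least 3.7-fold lower number from compound 2 to compound 3 (0.56 log units; beyond the scatter). The position on the sulfur therefore responds to the choice of aryl group, and a measured number is no longer confined to one analogue: compound 1 gives 2100 nM and compound 3 gives 2700 nM. The step has a floor but no full size, because compound 2 stands at a limit of the assay and not at a number: the limit of > 10000 nM in this assay, at which 1 of the 3 values shown sits.

The compounds shown leave open whether the step follows from the loss of the chlorine or from the arrival of the two methyl groups, and a ring with a single methyl would be needed to separate the two. They also give no reading on an amine or a carboxylic acid on this ring, or on a longer chain in place of the aryl group on the sulfur.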